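This account rests on a few compounds, and the source may have more. Where it says the series, first, only, none or still open, it means among the compounds named here.

Measured so far:
compound 1 `CC(C)[C@@H]1CC[C@@H](C)C[C@@]12N(C)C(=O)[C@@H]1[C@H]3C(=O)N(C)C(=O)[C@H]3ON12` — in a functional assay, with a stated time of 20 min, tested at 0.5 mg/mL (a higher number here means a stronger effect of the compound at the concentration tested, a lower number a weaker effect), compound 1 gives 18.2%
compound 2 `COc1ccc(N2C(=O)[C@H]3[C@H](ON4[C@@H]3C(=O)N(C)[C@@]43C[C@H](C)CC[C@H]3C(C)C)C2=O)cc1` — in this assay compound 2 gives 32.9%

Compound 2 holds the higher of the two numbers. For the measured compounds named here, the single measured step is a number 14.7 percentage points higher from compound 1 to compound 2 (beyond the scatter), made by putting 4-methoxyphenyl in place of methyl on an amide-type nitrogen in a ring.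

Compound 3 `Cc1cccc(N2C(=O)[C@H]3[C@H](ON4[C@@H]3C(=O)N(C)[C@@]43C[C@H](C)CC[C@H]3C(C)C)C2=O)c1` is not yet measured. Its change from compound 2 is 3-methylphenyl in place of 4-methoxyphenyl on an amide-type nitrogen in a ring. Going by the values given here, the one step available concerns an aryl group replacing methyl, not one aryl group replacing another, so it gives no direct guide; compound 3 keeps an aryl group in that place, as compound 2 does. The expectation is therefore no step beyond the scatter in this assay, with the direction undecided. Compound 3 is expected to give about 30%, within 16% to 44%. That expectation amounts to a step of a number 2.9 percentage points lower from compound 2 to compound 3 (within the scatter).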

Compound 3, a percentage reported as activity, at one concentration (the size of the read-out at that concentration, not a potency): 26.8%
Compound 3: the middle estimate sits 3.2 percentage points above what was measured; the range from low to high includes it.
By their numbers in this assay, from the lowest: compounds 1, 3 and 2 (each within the scatter of the next, the first and the last beyond it).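

In this assay the exchange of 4-methoxyphenyl for 3-methylphenyl on the amide-type nitrogen gives a number 6.1 percentage points lower from compound 2 to compound 3 (within the scatter), so these two aryl groups cannot be told apart at this position. Replacing methyl with 3-methylphenyl gives a number 8.6 percentage points higher from compound 1 to compound 3 (within the scatter), while 4-methoxyphenyl in the same place gives a number 14.7 percentage points higher from compound 1 to compound 2 (beyond the scatter), so only the latter aryl group separates from methyl and a gain from aryl groups in general is not established. No available evidence bears on the cause of these steps.

Going by these compounds, the two aryl groups differ in both the substituent and its place on the ring, so the contribution of each remains open. Also open, on these data alone, is how the read-out responds at this nitrogen to unsubstituted phenyl, or to a phenyl carrying a carboxylic acid or an amine.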